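The source may report more compounds than this note shows. Statements on the series, on what has been measured and on what is new or still open speak of the compounds shown alone.

Compound 2 `CCCCc1cn(C[C@H](O)[C@H]2OC(=O)C(OCc3ccccc3)=C2OCc2ccccc2)nn1` is one of two compounds that have been measured in a functional assay on CFPAC-1 cells (Homo sapiens) for antiproliferative activity, read by MTT assay, with a stated time of 72 h; a lower number here means a stronger inhibitor, a higher number a weaker inhibitor; in that assay compound 2 gives 73200 nM. For the measured compounds named here, its only neighbour among the measured compounds is compound 1 `O=C1O[C@H]([C@@H](O)Cn2cc(-c3cccc(O)c3)nn2)C(OCc2ccccc2)=C1OCc1ccccc1`, which carries 3-hydroxyphenyl where compound 2 carries butyl on an aromatic carbon, and in this assay compound 1 gives 54100 nM. The two numbers lie within the scatter of each other, as the step of a 1.4-fold higher number from compound 1 to compound 2 (0.13 log units; within the scatter) shows, so compound 2 stands level with the only comparator there is.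

Compound 3 `CCCCCc1ccc(-c2cn(C[C@H](O)[C@H]3OC(=O)C(OCc4ccccc4)=C3OCc3ccccc3)nn2)cc1` departs from compound 2 by a single change, (4-pentylphenyl in place of butyl on an aromatic carbon). Going by the values given here, the one measured step that bears on this change is a 1.4-fold higher number from compound 1 to compound 2 (0.13 log units; within the scatter), which exchanged an aromatic ring for a chain at the same place and moved the number by less than the scatter. Among the compounds with values here, nothing among the measured compounds speaks for a step beyond the scatter in this assay in either direction when the chain is in turn replaced by 4-pentylphenyl. The expected step is therefore small, a 1.2-fold lower number from compound 2 to compound 3 (0.09 log units; within the scatter). Compound 3 is estimated at 60000 nM, with a range from 25000 nM to 150000 nM.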

Compound 3, half-maximal inhibitory concentration: 9890 nM
Compound 3: the middle estimate sits 6.1-fold (0.78 log units) above what was measured, and the stated range ends above it.
By their numbers in this assay, from the lowest: compound 3; then compounds 1 and 2 (each within the scatter of the next).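

Compound 3 shows that the group on this aromatic carbon of the five-membered ring can move the number in this assay beyond the scatter: 4-pentylphenyl in place of butyl gives a 7.4-fold lower number from compound 2 to compound 3 (0.87 log units; beyond the scatter) and the earlier exchange at this place had not done so. The same group in place of 3-hydroxyphenyl gives a 5.5-fold lower number from compound 1 to compound 3 (0.74 log units; beyond the scatter) on the same core. An aromatic ring alone does not account for this pattern among the three compounds, since compound 1 carries one and still stands level with compound 2, which carries only a chain; no measurement here explains the step.

The compounds shown leave open whether the step belongs to the ring, to the pentyl chain or to the two together, which a plain phenyl and a longer chain such as octyl on the same ring could separate. They also leave open how this place would respond to an amine or a carboxylic acid at the end of the 4-substituent of that ring.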